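This account rests on a few compounds, and the source may have more. Where it says the series, first, only, none or still open, it means among the compounds named here.

Measured so far in a functional assay on BMEC cells (Bos taurus) for antiproliferative activity; a higher number here means a weaker inhibitor, a lower number a stronger inhibitor:
compound 1 `COc1cc(/C=C\Cc2cc(O)c3cc(C)sc3c2)cc(OC)c1OC`, 23 nM;
compound 2 `COc1cc(/C=C/Cc2cc(O)c3cc(C)oc3c2)cc(OC)c1OC`, 12300 nM;
compound 3 `COc1cc(/C=C/Cc2cc(O)c3cc(-c4ccccc4)oc3c2)cc(OC)c1OC`, for which only a limit is recorded.

In this assay compound 3 sits at the limit of > 20000 nM, the point at which (the limit of > 20000 nM in this assay, at which 1 of the 3 values shown sits). Compound 1 stands lowest of the two numbers; the difference between the two cores of compound 1 and compound 2 is not broken down here. From compound 2 to compound 3 the change is phenyl in place of methyl on an aromatic carbon; it gave an at least 1.6-fold higher number from compound 2 to compound 3 (0.21 log units; that floor lies within the scatter), and since compound 3 is a limit the true size is open.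

Compound 4 `COc1cc(/C=C\Cc2cc(O)c3cc(-c4ccccc4)sc3c2)cc(OC)c1OC` is not yet measured. It differs from compound 1 by phenyl in place of methyl on an aromatic carbon. This is the same kind of change as from compound 2 to compound 3, though the place is on an aromatic carbon of a five-membered aromatic ring with 1 sulfur, next to the ring sulfur, rather than with 1 oxygen, next to the ring oxygen. Resting on compound 2 to compound 3 in this assay, a loss is expected, a 6.5-fold higher number from compound 1 to compound 4 (0.81 log units; beyond the scatter), wider in range than that floor. Compound 4 is estimated at 150 nM, between 25 nM and 3000 nM.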

Compound 4, half-maximal inhibitory concentration: 23000 nM
Estimate against measurement, compound 4: 150-fold (2.19 log units) below; the whole stated range lies below it.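

In this assay, phenyl in place of methyl on an aromatic carbon carries a heavy cost on the core of compound 1, with a 1000-fold higher number from compound 1 to compound 4 (3.00 log units; beyond the scatter). Set beside the same change on the other core, the comparison stays unresolved: the same change on two cores in this assay, an at least 1.6-fold higher number (0.21 log units; that floor lies within the scatter) from compound 2 to compound 3 and a 1000-fold higher number (3.00 log units; beyond the scatter) from compound 1 to compound 4; the limit leaves it open whether they differ. Compound 3 is a limit at > 20000 nM, so nothing here shows whether the change costs the same on both cores.

The compounds shown leave open how an ethyl, an amine or a carboxylic acid in place of methyl would read on the core of compound 1. Going by these compounds, the cores of compound 1 and compound 2 differ in more than one place, so any part played by the ring sulfur alone also remains open.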